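The source may hold more compounds than are shown below. What is called first, only, known or untested is meant among the compounds shown, and "the series" means these compounds.

Measured compounds:
compound 1, `COc1cc(-c2cc(/C=C/C(=O)c3ccc(Cl)c(Cl)c3)[nH]n2)cc(OC)c1OC`, gives 96% in a functional assay on RXF 393 cells (Homo sapiens) for cytotoxicity, read by sulforhodamine B assay, with a stated time of 48 h, tested at 0.01 uM; a lower number here means a stronger effect, a higher number a weaker effect of the compound at the concentration tested.
compound 2, `COc1ccc(C(=O)/C=C/c2cc(-c3cc(OC)c(OC)c(OC)c3)n[nH]2)cc1`, gives 93% in this assay.

For the measured compounds named here, compound 2 has the lower of the two numbers measured so far, but its nearest neighbour, compound 1, differs from it by a step that stays within the scatter: a number 3 percentage points lower from compound 1 to compound 2 (within the scatter). On these two numbers alone compound 2 cannot be said to act more strongly than compound 1.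

Compound 3, `COc1cc(-c2cc(/C=C/C(=O)c3ccc(F)c(F)c3)[nH]n2)cc(OC)c1OC`, has not yet been measured. It differs from compound 2 in one place: 3,4-difluorophenyl in place of 4-methoxyphenyl on a carbonyl carbon. Going by the values given here, the only step that bears on this change is the one from compound 1 to compound 2, which swapped a 3,4-dichlorophenyl for the same 4-methoxyphenyl on the carbonyl carbon and was within the scatter. Replacing that group again with a halogen-bearing ring is therefore expected to give no step beyond the scatter, a number 2 percentage points higher from compound 2 to compound 3 (within the scatter). Compound 3 is estimated at 95% in this assay, with a range from 86% to 103%.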

Compound 3, a percentage reported as activity, at one concentration (the size of the read-out at that concentration, not a potency): 94%
Compound 3: the middle estimate sits 1 percentage points above what was measured, and the stated range covers the measured number.
By their numbers in this assay, from the lowest: compounds 2, 3 and 1 (each within the scatter of the next).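

At this place, on a carbonyl carbon whose other neighbours are the double-bonded chain carbon, a third aromatic ring now gives the same picture in this assay: there is a number 1 percentage points higher from compound 2 to compound 3 (within the scatter) and a number 2 percentage points lower from compound 1 to compound 3 (within the scatter). The 3,4-difluorophenyl ring can therefore stand in for either 3,4-dichlorophenyl or 4-methoxyphenyl without a readable change in this number, even though it carries no hydrogen-bond acceptor and 4-methoxyphenyl carries one. No measurement at hand explains why these rings read alike.

All three compounds lie within the scatter of one another, so nothing yet shows that a change at this place can move the number at all. From the compounds shown here alone, it remains open whether a carboxylic acid or an amine on the ring, or a longer carbon chain in place of the ring, would do so.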